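From 3-chlorophenyl to 3-bromophenyl in the series

The source may report more compounds than this note shows. Statements on the series, on what has been measured and on what is new or still open speak of the compounds shown alone.

Going by the values given here, compound 1 `NC1=NC2(CCSCC2)N(OCCCOc2cccc(Cl)c2)C(N)=N1` gives 1 nM in a functional assay on HCT-116 cells (Homo sapiens) for antiproliferative activity, read by MTT assay, with a stated time of 72 h (a higher number here means a weaker inhibitor, a lower number a stronger inhibitor), the lowest of the two numbers so far. Compound 2 `Cc1ccc(OCCCON2C(N)=NC(N)=NC23CCOCC3)cc1` gives 2390 nM in this assay, a gap well beyond the scatter. Among the compounds with values here, no two measured compounds differ in one place only, so this gap cannot be assigned to any single structural change.

Compound 3 `NC1=NC2(CCSCC2)N(OCCCOc2cccc(Br)c2)C(N)=N1` keeps the core of compound 1 and carries one change: bromo in place of chloro on an aromatic carbon. This is bromo in place of chloro on an aromatic carbon, meta to a large group. Within the data shown here, with no measured step to draw on, only a small upward move in this assay is expected, and possibly none beyond the scatter. The estimated step is a 2.0-fold higher number from compound 1 to compound 3 (0.30 log units; within the scatter). For compound 3 the expected value is 2 nM, with an estimated range of 0.5 nM to 20 nM.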

Compound 3, half-maximal inhibitory concentration: 1 nM
Compound 3: the middle estimate sits 2.0-fold (0.30 log units) above what was measured, within the range that was stated.
By their numbers in this assay, from the lowest: compounds 1 and 3 (each within the scatter of the next); then compound 2.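

In this assay, going by these compounds alone, bromo in place of chloro on this aromatic carbon, meta to a large group, gives no change at the digits printed from compound 1 to compound 3 (within the scatter), the first step that can be read at a single place. At this position, chloro and bromo therefore cannot be told apart in this read-out, and compound 3 stays at 1 nM on the core of compound 1. No measured evidence bearing on why the two halogens read alike is at hand.

Going by these compounds, whether this holds beyond these two halogens remains open: fluoro, iodo, methoxy or an amine on the same aromatic carbon could read differently in this assay. The wide gap to compound 2 also remains unassigned, and a compound differing from compound 1 only in the chain or only in the sulfur-containing part of the core would be needed to place it.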